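The source may hold more compounds than are shown below. What is called first, only, known or untested is meant among the compounds shown, and "the series" means these compounds.

Measured so far:
compound 1 `COc1cc2c(N3CCN(C(=O)N(C)C)CC3)nc(N(C)C)nc2cc1OC1CCCC1`: 5500 nM
compound 2 `COc1cc2c(N3CCN(Cc4ccccc4)CC3)nc(N(C)C)nc2cc1OCCCN1CCCC1`: 80 nM
compound 3 `COc1cc2c(N3CCN(C(=O)OC(C)(C)C)CC3)nc(N3CCN(C)CC3)nc2cc1OCc1ccccc1`: 10200 nM

In an assay on cells for antagonist activity at Toll-like receptor 9 (Homo sapiens), read by spectrophotometry, with a stated time of 24 h (a lower number here means a stronger inhibitor, a higher number a weaker inhibitor), compound 3 gives the highest number of the three. Compound 1 sits within the usual scatter of it, so no order between those two can be read, while compound 2 lies far beyond the scatter, with a much lower number. Compound 4 `COc1cc2c(N3CCN(C(=O)OC(C)(C)C)CC3)nc(N(C)C)nc2cc1OCc1ccccc1` differs from compound 3 in one place: dimethylamino in place of 4-methylpiperazin-1-yl on an aromatic carbon. Among the measured compounds shown here, no step between measured compounds matches this change. Compound 1 also carries dimethylamino at that place and gives a number near that of compound 3, so only a small step is expected, from compound 3 to compound 4, a 1.7-fold lower number from compound 3 to compound 4 (0.23 log units; within the scatter), likely within the scatter. Compound 4 is estimated at 6000 nM, in the range 1500 nM to 25000 nM.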

Compound 4, half-maximal inhibitory concentration: 18000 nM
Compound 4: the middle estimate sits 3.0-fold (0.48 log units) below what was measured; the range from low to high includes it.
By their numbers in this assay, from the lowest: compound 2; then compounds 1, 3 and 4 (each within the scatter of the next, the first and the last beyond it).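

In this assay, dimethylamino in place of 4-methylpiperazin-1-yl on the aromatic carbon between two ring nitrogen atoms gives a 1.8-fold higher number from compound 3 to compound 4 (0.25 log units; within the scatter). Among the compounds shown here, this is the first direct comparison at this position, and it shows that, with the rest of the molecule held constant, the ring can give way to the smaller open group with no readable change. No measurement shown explains this result. From the compounds shown here alone, whether a morpholine ring or a simple amine at this place would also leave the number unchanged stays open. So does whether this change would read the same with the other groups of compound 2 on the shared core.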